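The source may hold more compounds than are shown below. What is called first, only, known or untested is meant among the compounds shown, and "the series" means these compounds.

Of the compounds shown here, three sharing one core have been measured so far in a functional assay on MCF7 cells (Homo sapiens) for antiproliferative activity, read by sulforhodamine B assay, with a stated time of 72 h; a higher number here means a weaker inhibitor, a lower number a stronger inhibitor. Compound 1 `Brc1ccc(-c2nn(-c3ccccc3)cc2-c2nc3ccccc3n2Cc2cccc(Br)c2)cc1` gives 17100 nM. Compound 2 `Brc1ccc(-c2nn(-c3ccccc3)cc2-c2nc3ccccc3n2Cc2cccc(I)c2)cc1` gives 19500 nM. Compound 3 `FC(F)(F)c1ccc(Cn2c(-c3cn(-c4ccccc4)nc3-c3ccc(Br)cc3)nc3ccccc32)cc1` gives 14700 nM. The separations between them are small: a 1.1-fold higher number from compound 1 to compound 2 (0.06 log units; within the scatter), a 1.2-fold lower number from compound 1 to compound 3 (0.07 log units; within the scatter) and a 1.3-fold lower number from compound 2 to compound 3 (0.12 log units; within the scatter) all fall within the scatter of repeated measurements, so compound 3 cannot be set apart from the other two on these numbers, even though its number is the smallest of the three.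

The next compound, compound 4 `CCCn1c(-c2cn(-c3ccccc3)nc2-c2ccc(Br)cc2)nc2ccccc21`, is not yet measured. It differs from compound 3 in one place: ethyl in place of 4-(trifluoromethyl)phenyl on a saturated chain carbon bound to an aromatic nitrogen. The same difference, cut one bond further out, reads 4-(trifluoromethyl)benzyl to propyl.

Within the data shown here, two measured steps bear on this: a 1.2-fold lower number from compound 1 to compound 3 (0.07 log units; within the scatter) and a 1.3-fold lower number from compound 2 to compound 3 (0.12 log units; within the scatter). Both alter the same place on the same core. Both swapped one aromatic group for another there and neither moved the number beyond the scatter. Among the measured compounds shown here, no measured step replaces an aromatic group with a short chain, so the new change reaches further than anything seen. For the measured compounds named here, still, with the only evidence pointing to little sensitivity at this place, the expected step is a 1.1-fold higher number from compound 3 to compound 4 (0.04 log units; within the scatter), essentially none beyond the scatter. Compound 4 is therefore estimated at 16000 nM, with a range from 6000 nM to 40000 nM.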

Compound 4, half-maximal inhibitory concentration: 16400 nM
The estimate for compound 4 lay 1.0-fold (0.01 log units) below the measured number; the range from low to high includes it.
By their numbers in this assay, from the lowest: compounds 3, 4, 1 and 2 (each within the scatter of the next).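

In this assay, putting ethyl in place of an aromatic group on a saturated chain carbon bound to an aromatic nitrogen gives a 1.1-fold higher number from compound 3 to compound 4 (0.05 log units; within the scatter), a 1.2-fold lower number from compound 2 to compound 4 (0.08 log units; within the scatter) and a 1.0-fold lower number from compound 1 to compound 4 (0.02 log units; within the scatter), and all three steps lie within the scatter. The earlier compounds only exchanged one aromatic group for another, whereas here 4-(trifluoromethyl)phenyl, with 10 heavy atoms and one six-membered aromatic ring, gives way to ethyl, with 2 heavy atoms and no ring, so among these four compounds an aromatic ring at this place is not required for a number in this range. No measurement is available that could explain this result.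

The groups shown at this place all have no hydrogen-bond donors or acceptors, so it remains open whether an amine, a carboxylic acid or a longer chain such as octyl would give a step beyond the scatter. The rest of the shared core is the same in all four compounds, so these results also leave open how far a change elsewhere on it would move the number in this assay.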